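A few compounds are considered here, and "the series" means these few. Any claim that something is new, unique, unknown or untested is made for them only; others in the source may bear on it.

Compound 1: `CCOc1ccc2nc(C(F)(F)F)cc(OCC(=O)Nc3cc(C)cc(C)c3)c2c1`, < 1000 nM. Compound 2: `COc1cccc(NC(=O)COc2cc(C)nc3ccc(OC)cc23)c1`, 35000 nM.

In a physicochemical assay for solubility, in phosphate buffer, measured as kinetic solubility, with a stated time of 1 h, at pH 7.4 (on this read-out lower numbers stand for lower solubility and higher numbers for higher solubility), compound 1 gives < 1000 nM, and this is a limit of the assay rather than a number. In this assay compound 2 gives 35000 nM. Going by the values given here, compound 2 therefore carries the only number among the measured pair; the other entry sits at the limit of < 1000 nM in this assay, at which 1 of the 2 values shown sits, so no step between measured compounds can be drawn from these two.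

Compound 3, `COc1ccc2nc(C)cc(OCC(=O)Nc3ccncn3)c2c1`, has not yet been measured in this assay. It differs from compound 2 in one place: pyrimidin-4-yl in place of 3-methoxyphenyl on an amide-type nitrogen. Among the compounds with values here, with no measured step to lean on, the expected step from compound 2 to compound 3 is a 2.3-fold higher number from compound 2 to compound 3 (0.36 log units; beyond the scatter), modestly upward, likely just beyond the usual scatter. On that basis compound 3 is expected to give 80000 nM in this assay, within a range from 25000 nM to 250000 nM.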

Compound 3, solubility: 27500 nM
For compound 3 the middle estimate is 2.9-fold (0.46 log units) above the measured one; the measured number falls inside the stated range.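

In this assay, going by these compounds alone, the change from 3-methoxyphenyl to pyrimidin-4-yl on the amide-type nitrogen gives a 1.3-fold lower number from compound 2 to compound 3 (0.10 log units; within the scatter), the first step that can be read at this position. At this place, therefore, a six-membered aromatic ring of carbon only and one with 2 hetero atoms are not told apart by this read-out, even though the entering group has 6 heavy atoms against 8 and 2 hydrogen-bond acceptors against 1. Compound 2 and compound 3 both give numbers, so this step does not rest on the one limit in the set: the limit of < 1000 nM in this assay, at which 1 of the 3 values shown sits.

Going by these compounds, whether the same holds for a non-aromatic group on that nitrogen, such as a piperidine, a longer alkyl chain, or a phenyl ring carrying an amine or a carboxylic acid, stays open. On these data alone, compound 1 differs from the others in more than one place, so what its trifluoromethyl and ethoxy groups each contribute also stays open.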